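Methoxy for chloro on a quinolone antiproliferative series

The compounds below may be only part of what the source reports. "The series", "measured", "known", "first", "only" and "open" are said of these compounds alone.

Four compounds share a core built around a quinolone fused to a piperazine-bearing ring, and differ in the aryl group attached to it and in the group on the ring nitrogen. Compound 1 `CCn1cc(-c2ccc(Cl)cc2)c(=O)c2cc(F)c(N3CCNCC3)cc21` carries a 4-chlorophenyl group; in a functional assay on BGC-823 cells (Homo sapiens) for antiproliferative activity, read by MTT assay, with a stated time of 48 h (a higher number here means a weaker inhibitor, a lower number a stronger inhibitor), compound 1 gives 14600 nM. Compound 2 `CCn1cc(-c2ccc(OC)cc2)c(=O)c2cc(F)c(N3CCNCC3)cc21` differs from it only by methoxy in place of chloro on an aromatic carbon, and in this assay compound 2 gives 46100 nM. This change gave a 3.2-fold higher number from compound 1 to compound 2 (0.50 log units; beyond the scatter).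

Compound 3 `O=c1c(-c2cccc(Cl)c2)cn(C2CC2)c2cc(N3CCNCC3)c(F)cc12` has a different core from compound 1; the difference between the two cores is not broken down here. In this assay compound 3 gives 610 nM, the lowest of the three measured numbers. Compound 4 `COc1cccc(-c2cn(C3CC3)c3cc(N4CCNCC4)c(F)cc3c2=O)c1` differs from compound 3 by methoxy in place of chloro on an aromatic carbon. The place differs from that in the first pair: there the methoxy stands para to a large group, here meta to a large group, so this is the same kind of change rather than the same change.

Because the earlier pair showed a 3.2-fold higher number from compound 1 to compound 2 (0.50 log units; beyond the scatter), a step of similar direction is expected here, with some allowance for the other core and position, and the step expected is a 3.0-fold higher number from compound 3 to compound 4 (0.47 log units; beyond the scatter). Compound 4 is therefore estimated at 1800 nM, expected to fall between 700 nM and 5000 nM.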

Compound 4, half-maximal inhibitory concentration in the BGC-823 assay: 690 nM
For compound 4 the middle estimate is 2.6-fold (0.42 log units) above the measured one, outside the stated range (below it).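

In the BGC-823 assay, putting methoxy in place of chloro gives a 1.1-fold higher number from compound 3 to compound 4 (0.05 log units; within the scatter), so on the core of compound 3 this change leaves no mark that can be told apart from the ordinary spread of repeated measurements. The step seen on the first core therefore did not carry over in size to the second: the same change on two cores in the BGC-823 assay, a 3.2-fold higher number (0.50 log units; beyond the scatter) from compound 1 to compound 2 and a 1.1-fold higher number (0.05 log units; within the scatter) from compound 3 to compound 4, 2.8-fold (0.45 log units) apart, beyond the scatter of two such steps. What this does not show is which difference between the two pairs sets their steps apart, as the group on the ring nitrogen, the place of the swapped group on the phenyl ring and the rest of the core all change together, and two pairs cannot separate these.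

In a physicochemical assay for solubility, at pH 7.9 (a lower number here means a less soluble compound, a higher number a more soluble compound), compound 3 gives > 400000 nM, which is a limit of the assay and not a number. In the physicochemical assay compound 4 gives > 400000 nM, which is likewise a limit of the assay and not a number. In the physicochemical assay the step from compound 3 to compound 4 cannot be read, as both entries are limits of the assay and not numbers: the limit of > 400000 nM in the physicochemical assay, at which 2 of the 2 values shown sit. Also open, going by these compounds, is whether the result on the core of compound 3 would hold for another group at the same place, such as trifluoromethyl or a carboxylic acid, and whether 3-chlorophenyl to 3-methoxyphenyl on the core of compound 1 would give a step like the one from that core's first pair.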